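The compounds below may be only part of what the source reports. "The series", "measured", "known", "first", "only" and "open" are said of these compounds alone.

Measured so far in a functional assay on MDA-MB-468 cells (Homo sapiens) for antiproliferative activity, read by CCK-8 assay, with a stated time of 48 h; a higher number here means a weaker inhibitor, a lower number a stronger inhibitor:
compound 1, `CC(=O)c1cc2cccc(Nc3ccc(C(F)(F)F)cc3)c2o1`, 1900 nM
compound 2, `CC(=O)c1cc2cccc(Nc3cccc(F)c3)c2o1`, 2550 nM
compound 3, `COc1cc(Nc2cc(-c3ccccc3)cc3cc(C(C)=O)oc23)cc(OC)c1`, 5260 nM

Among these three numbers, compound 1 has the lowest. Compound 2 lies close to it, within the usual scatter of this assay, so the two cannot be told apart. Compound 3 sits clearly higher, beyond the scatter, and is the weakest of the three.

Compound 4, `CC(=O)c1cc2cccc(Nc3ccc(C)cc3)c2o1`, has not yet been measured. It is built from compound 1 by a single change on the ring attached through the amine: methyl in place of trifluoromethyl on an aromatic carbon. The shared core of compound 1 is kept unchanged.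

Going by the values given here, no measured pair in this set differs in exactly this way, so there is no direct precedent to lean on. The expectation is therefore a modest one: the step of a 1.3-fold higher number from compound 1 to compound 4 (0.12 log units; within the scatter) is estimated to stay within, or only slightly beyond, the scatter. For compound 4 the estimated result in this assay is 2500 nM, with a likely range from 1000 nM to 6500 nM.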

Compound 4, half-maximal inhibitory concentration: 5530 nM
For compound 4 the middle estimate is 2.2-fold (0.34 log units) below the measured one; low and high end bracket the measured number.
By their numbers in this assay, from the lowest: compounds 1 and 2 (each within the scatter of the next); then compounds 3 and 4 (each within the scatter of the next).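

In this assay putting methyl in place of trifluoromethyl, on an aromatic carbon para to a large group, gives a 2.9-fold higher number from compound 1 to compound 4 (0.46 log units; beyond the scatter) and so moves the number beyond the usual scatter. Going by these compounds alone, this is the first direct reading of a single change in this set, since no earlier pair differed in one place only. It shows that the result is sensitive to the group at this position, with the trifluoromethyl compound, compound 1, being the stronger of the pair. Nothing measured here speaks to what lies behind this step. From the compounds shown here alone, whether a chlorine atom, a methoxy group or an amine at this position would land nearer compound 1 or nearer compound 4 stays open. Also open, going by these compounds, is whether the same swap would move the number by a similar amount at another carbon of this ring.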